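The source may hold more compounds than are shown below. What is called first, only, known or untested is meant among the compounds shown, and "the series" means these compounds.

- compound 1 `CCN(CC)CC(=O)OC1CC2(N(C)C)CC(c3ccccc3)C1C(c1ccccc1)C2`: 30100 nM
- compound 2 `CCN(CC)CC(=O)OC1CC2(N3CCCC3)CC(c3ccccc3)C1C(c1ccccc1)C2`: 49000 nM

For the measured compounds named here, in an ADME assay on L6 cells (Rattus norvegicus) for cytotoxicity, read by resazurin assay, with a stated time of 72 h (a higher number here means a weaker inhibitor, a lower number a stronger inhibitor), compound 1 stands within the scatter of compound 2, the only other compound measured so far, so the two numbers cannot be told apart. Compound 3 `CN(C)C12CC(OC(=O)CN3CCCCC3)C(C(c3ccccc3)C1)C(c1ccccc1)C2` keeps the core of compound 1 and changes one group: piperidin-1-yl in place of diethylamino on a saturated chain carbon bound to a carbonyl carbon. In words, piperidin-1-yl replaces diethylamino on a saturated chain carbon bound to a carbonyl carbon. Going by the values given here, no measured compound carries a change at that place. Among the compounds with values here, the one measured step that bears on it, and only loosely, is pyrrolidin-1-yl in place of dimethylamino on a saturated ring carbon, which gave a 1.6-fold higher number from compound 1 to compound 2 (0.21 log units; within the scatter). On that evidence, no step beyond the scatter is expected in this assay. The expected change is a 1.2-fold higher number from compound 1 to compound 3 (0.07 log units; within the scatter). For compound 3 the estimated value is 35000 nM, with an expected range from 15000 nM to 75000 nM.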

Compound 3, half-maximal inhibitory concentration: 29300 nM
The estimate for compound 3 lay 1.2-fold (0.08 log units) above the measured number, within the range that was stated.
By their numbers in this assay, from the lowest: compounds 3, 1 and 2 (each within the scatter of the next).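

Tying the two ethyl arms of diethylamino into a ring gives the first direct look at this place: with piperidin-1-yl on the saturated chain carbon bound to a carbonyl carbon, this assay shows a 1.0-fold lower number from compound 1 to compound 3 (0.01 log units; within the scatter) and nothing more. At this one place and on the core of compound 1, then, replacing the open-chain amine with the six-membered ring gives a number that cannot be told apart from the original. No supporting data are available to explain this result.

On these data alone, whether the same holds for a morpholin-4-yl group, with a ring oxygen, or for a primary amine at this place remains open. So does the effect of a longer chain between the carbonyl and the amine, or of a carboxylic acid in place of the amine.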